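The source may hold more compounds than are shown below. What is called first, only, known or untested is meant among the compounds shown, and "the series" means these compounds.

In an ADME assay on HepG2 cells (Homo sapiens) for cytotoxicity, read by fluorescence and resazurin assay, with a stated time of 24 h (a lower number here means that less compound is tolerated, a higher number that more compound is tolerated), compound 1 (`O=S1(=O)C=C(Sc2nnc(-c3cccnc3)o2)c2ccccc21`) gives 14000 nM and compound 2 (`O=S1(=O)C=C(Sc2nnc(C3CCCCC3)o2)c2ccccc21`) gives 15000 nM, while compound 3 (`Nc1ccc(-c2nnc(SC3=CS(=O)(=O)c4ccccc43)o2)cc1`) gives 24000 nM in the same read-out. Compound 3 therefore cannot be separated from the other two (a 1.7-fold higher number from compound 1 to compound 3 (0.23 log units; within the scatter) and a 1.6-fold higher number from compound 2 to compound 3 (0.20 log units; within the scatter)). Compound 4 (`COc1ccccc1-c1nnc(SC2=CS(=O)(=O)c3ccccc32)o1`) carries 2-methoxyphenyl in place of 4-aminophenyl on an aromatic carbon of the five-membered aromatic ring (2-methoxyphenyl in place of 4-aminophenyl on an aromatic carbon). The measured steps that bear on this change are exchanges at that same place. Besides the two above, there is one more (a 1.1-fold higher number from compound 1 to compound 2 (0.03 log units; within the scatter)), and all three stay within the scatter across pyridin-3-yl, cyclohexyl and 4-aminophenyl. None of them involves 2-methoxyphenyl, so this read-across is limited. In this assay, no step beyond the scatter is expected, and the expected change is a 1.3-fold lower number from compound 3 to compound 4 (0.12 log units; within the scatter) on this thin evidence. The estimate for compound 4 is 18000 nM (expected range 8000 nM to 40000 nM).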

Compound 4, half-maximal cytotoxic concentration: 16000 nM
Compound 4: the middle estimate sits 1.1-fold (0.05 log units) above what was measured, within the range that was stated.
By their numbers in this assay, from the lowest: compounds 1, 2, 4 and 3 (each within the scatter of the next).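

In this assay, 2-methoxyphenyl on the aromatic carbon of the five-membered ring adds a fourth group at this position that cannot be separated from the other three (a 1.5-fold lower number from compound 3 to compound 4 (0.18 log units; within the scatter); a 1.1-fold higher number from compound 2 to compound 4 (0.03 log units; within the scatter); a 1.1-fold higher number from compound 1 to compound 4 (0.06 log units; within the scatter)). Among these compounds, this is also the first exchange here of 4-aminophenyl, with its hydrogen-bond donor, for a group carrying an oxygen and no hydrogen-bond donor, and the loss of that donor leaves no readable step. No supporting measurement bears on this result.

From the compounds shown here alone, whether a carboxylic acid, an amine on a longer chain or a small methyl group at this place would give a step beyond the scatter stays open. The contribution of the shared core also stays unread, as all four compounds carry it unchanged.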